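Replacing the sulfonamide of compound 1 with a carboxyethyl chain

The source may hold more compounds than are shown below. What is called first, only, known or untested is meant among the compounds shown, and "the series" means these compounds.

The series is followed in an assay on HeLa cells with Bile acid receptor (Homo sapiens) as the target, read by a luciferase reporter, with a stated time of 24 h; on this read-out lower numbers stand for an effect already at smaller amounts and higher numbers for an effect only at larger amounts of compound. Among the compounds with values here, compound 1 `CC(C)(C)c1ccc(C(=O)NCc2ccc(NS(C)(=O)=O)cc2)cc1` gives 44 nM, the lowest of the three numbers measured so far. Compound 2 `O=C(O)c1ccc(CNC(=O)c2cccc(-c3ccccc3)c2)cc1` gives 670 nM, a higher number beyond the scatter, and compound 3 `CC(C)(C)c1ccc(C(=O)NCc2ccc(C(=O)O)cc2Cl)cc1` gives 7500 nM, the furthest from compound 1 and also beyond the scatter. Within the data shown here, no two measured compounds differ in a single place, so no single step is directly known. Compound 4 `CC(C)(C)c1ccc(C(=O)NCc2ccc(CCC(=O)O)cc2)cc1` differs from compound 1 by 2-carboxyethyl in place of methanesulfonamido on an aromatic carbon, placed on an aromatic carbon of a six-membered aromatic ring of carbon only, para to a large group. Compound 2 and compound 3 both carry a carboxylic acid and both give higher numbers than compound 1, though neither is a one-place comparison. A moderate step toward higher numbers is expected a 6.8-fold higher number from compound 1 to compound 4 (0.83 log units; beyond the scatter). Compound 4 is estimated at 300 nM, within 60 nM to 1500 nM.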

Compound 4, half-maximal effective concentration: 350 nM
Compound 4: middle estimate off by 1.2-fold (0.07 log units), on the low side; the measured number falls inside the stated range.
By their numbers in this assay, from the lowest: compound 1; then compounds 4 and 2 (each within the scatter of the next); then compound 3.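

This position now has its first one-place step: 2-carboxyethyl in place of methanesulfonamido gives an 8.0-fold higher number from compound 1 to compound 4 (0.90 log units; beyond the scatter). The leaving and entering groups have the same heavy-atom and hydrogen-bond donor counts but differ in their atoms and acceptor counts, so the step shows that the read-out depends on more than those matched counts. No measurement at hand explains the step.

Still open, as far as these compounds go, is how a shorter carboxymethyl chain or a longer 3-carboxypropyl chain would read at this position. Also open, from the compounds shown here alone, is whether a primary amide at the end of the chain would move the number in either direction.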